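Three Tails Measured, a Fourth to Be Expected

The source may hold more compounds than are shown below. What is called first, only, known or untested is meant among the compounds shown, and "the series" means these compounds.

Three compounds share one core and differ only in the group attached to an oxygen on a saturated carbon. Compound 1 `CC(C)[C@H](NC(=O)COc1cccc2ccccc12)C(=O)N[C@@H](CC(=O)O)C(=O)COC(=O)c1c(Cl)cccc1Cl` gives 11500 nM in a functional assay with Homo sapiens as the target; on this read-out lower numbers stand for stronger inhibition and higher numbers for weaker inhibition. Compound 2 `CC(C)[C@H](NC(=O)COc1cccc2ccccc12)C(=O)N[C@@H](CC(=O)O)C(=O)COc1cccc2ccccc12` gives 19000 nM in this assay, and compound 3 `CC(C)[C@H](NC(=O)COc1cccc2ccccc12)C(=O)N[C@@H](CC(=O)O)C(=O)COc1ccc2ccccc2c1` gives 15900 nM. Compound 3 thus holds the second highest of the three numbers; its nearest neighbour is compound 2 and its furthest is compound 1, and both of those gaps lie within the usual scatter of repeated measurements.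

Compound 4 `CC(C)[C@H](NC(=O)COc1cccc2ccccc12)C(=O)N[C@@H](CC(=O)O)C(=O)COc1cccc(C(F)(F)F)c1` is the next variation at the same place: 3-(trifluoromethyl)phenyl in place of naphthalen-2-yl on an oxygen on a saturated carbon. Among the measured compounds shown here, the steps that bear on this change are the ones that altered the same position: a 1.4-fold higher number from compound 1 to compound 3 (0.14 log units; within the scatter) and a 1.2-fold lower number from compound 2 to compound 3 (0.08 log units; within the scatter), together with a 1.7-fold higher number from compound 1 to compound 2 (0.22 log units; within the scatter). Every change tried at this oxygen so far has stayed within the scatter, so no step beyond the scatter is expected in this assay in either direction, though the new group has not itself been tested.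

Compound 4 is therefore estimated at 15000 nM, with a range from 7000 nM to 35000 nM. The step expected from this estimate is a 1.1-fold lower number from compound 3 to compound 4 (0.03 log units; within the scatter).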

Compound 4, half-maximal inhibitory concentration: 16600 nM
Estimate against measurement, compound 4: 1.1-fold (0.04 log units) below; the measured number falls inside the stated range.
By their numbers in this assay, from the lowest: compounds 1, 3, 4 and 2 (each within the scatter of the next).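

Among the compounds shown here, compound 4 is the first tail here with a single aromatic ring and no carbonyl on this oxygen, and it carries trifluoromethyl where naphthalen-2-yl has a second aromatic ring. In this assay that exchange gives a 1.0-fold higher number from compound 3 to compound 4 (0.02 log units; within the scatter), while the comparisons with the other two tails give a 1.1-fold lower number from compound 2 to compound 4 (0.06 log units; within the scatter) and a 1.4-fold higher number from compound 1 to compound 4 (0.16 log units; within the scatter), so all four tails now read alike, whether they have one aromatic ring or two and whether or not they contain fluorine or chlorine. No measurement shown bears on why these different tails give such similar numbers.

On these data alone, all four tails still contain an aromatic ring, so it remains open whether a plain saturated chain such as butyl, or a small group such as methyl, would read the same at this oxygen. For the compounds shown here, it also remains open whether an amine or a carboxylic acid on the phenyl ring of compound 4 would produce the first step beyond the scatter at this position.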